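Swapping a Carboxy Group for Fluorophenyl on a Styryl Arm

A few compounds are considered here, and "the series" means these few. Any claim that something is new, unique, unknown or untested is made for them only; others in the source may bear on it.

Measured compounds:
Compound 1: `COC(=O)/C=C/c1cccc(N(Cc2cc(OC)cc(OC)c2)C(=O)C2CCCCC2)c1`, giving 603 nM
Compound 2: `COC(=O)/C=C/c1cccc(N(Cc2ccc(/C=C/C(=O)O)cc2)C(=O)C2CCCCC2)c1`, giving 1000 nM

Both compounds were tested in an assay on isolated protein with Bile acid receptor (Homo sapiens) as the target; on this read-out lower numbers stand for an effect already at smaller amounts and higher numbers for an effect only at larger amounts of compound. The two share one core and differ only in the group on a saturated chain carbon bound to an amide-type nitrogen. For the measured compounds named here, the single comparison available, a 1.7-fold higher number from compound 1 to compound 2 (0.22 log units; within the scatter), shows that this exchange left the read-out essentially unchanged. Compound 2 therefore sits within the scatter of compound 1, and nothing in these two numbers separates them.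

Compound 3, `COC(=O)/C=C/c1cccc(N(Cc2ccc(/C=C/c3ccc(F)cc3)cc2)C(=O)C2CCCCC2)c1`, is the next compound and has not yet been measured in this assay. Relative to compound 2 it carries 4-fluorophenyl in place of carboxy on a double-bonded chain carbon bound to a double-bonded chain carbon. Going by the values given here, no measured step covers this particular change, since the only step known alters a different part of the molecule and was itself within the scatter. With no guidance either way, the change is expected to be a 2.0-fold lower number from compound 2 to compound 3 (0.30 log units; within the scatter), though the range is kept wide. For compound 3 the estimate in this assay is 500 nM, expected to fall between 120 nM and 2000 nM.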

Compound 3, half-maximal effective concentration: 186 nM
Compound 3: the middle estimate sits 2.7-fold (0.43 log units) above what was measured; measured number inside the range.
By their numbers in this assay, from the lowest: compound 3; then compounds 1 and 2 (each within the scatter of the next).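

In this assay, turning the 2-carboxyethenyl arm into 2-(4-fluorophenyl)ethenyl gives a 5.4-fold lower number from compound 2 to compound 3 (0.73 log units; beyond the scatter) and is the only step shown so far that lies beyond the usual scatter. The group on a double-bonded chain carbon bound to a double-bonded chain carbon therefore has a clear effect on this read-out, whereas the earlier exchange on a saturated chain carbon bound to an amide-type nitrogen, a 1.7-fold higher number from compound 1 to compound 2 (0.22 log units; within the scatter) in this assay, stayed within the scatter. The new exchange removes a hydrogen-bond donor and a hydrogen-bond acceptor and adds an aromatic ring in a single move, and no measurement at hand says which of these changes accounts for the lower number. The compounds shown leave open whether the fluorine contributes at all, a question that an unsubstituted phenyl in the same place could separate from the effect of the ring. They also leave open whether a ring is needed there, or whether a simple amide or a methyl group in place of the carboxy group would give a similar number.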